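A few compounds are considered here, and "the series" means these few. Any claim that something is new, unique, unknown or untested is made for them only; others in the source may bear on it.

Measured so far:
compound 1 `O=C(NN=C(c1ccccn1)c1ccccn1)c1ccc([N+](=O)[O-])cc1` – 260 nM
compound 2 `O=C(NN=C(c1ccccn1)c1ccccn1)c1ccc(O)cc1` – 7530 nM

In an ADME assay on cells (Homo sapiens) for antiproliferative activity, read by MTT assay (on this read-out lower numbers stand for stronger inhibition and higher numbers for weaker inhibition), compound 1 gives 260 nM, and compound 2 gives 7530 nM. Compound 2 thus holds the highest of the two numbers known in this assay, with compound 1 as its only neighbour; the single step shown, a 29-fold higher number from compound 1 to compound 2 (1.46 log units; beyond the scatter), is large and beyond the scatter.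

Compound 3 `O=C(NN=C(c1ccccn1)c1ccccn1)c1ccc(C(F)(F)F)cc1` differs from compound 2 in one place: trifluoromethyl in place of hydroxy on an aromatic carbon. Among the measured compounds shown here, the only measured step that bears on this is the one from compound 1 to compound 2, in which a hydroxy entered in place of a nitro and the number rose sharply. The change to compound 3 removes that hydroxy again, though what enters is a trifluoromethyl rather than a nitro, so the data do not fix how far the number returns.

On this basis a clear drop in this assay is expected for compound 3, estimated as an 8.4-fold lower number from compound 2 to compound 3 (0.92 log units; beyond the scatter). Compound 3 is therefore estimated at 900 nM, within a range of 200 nM to 4000 nM.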

Compound 3, half-maximal inhibitory concentration: 240 nM
Beside the measured number, compound 3's estimate is 3.8-fold (0.57 log units) above it; the measured number falls inside the stated range.
By their numbers in this assay, from the lowest: compounds 3 and 1 (each within the scatter of the next); then compound 2.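

Trifluoromethyl in place of hydroxy gives a 31-fold lower number from compound 2 to compound 3 (1.50 log units; beyond the scatter) in this assay, so the high number of compound 2 falls away with a group other than nitro as well. The pair without hydroxy shows a 1.1-fold lower number from compound 1 to compound 3 (0.03 log units; within the scatter), which means that the low number of compound 1 is not unique to nitro at this position and that, among the three groups shown, only hydroxy stands apart. Nothing available explains why hydroxy separates from nitro and trifluoromethyl here, and the difference in heavy atoms and hydrogen-bond donors between hydroxy and trifluoromethyl remains a count and not a cause.

Three groups at one position cannot show whether the high number belongs to hydroxy alone or would also appear with an amine, a methoxy group or a carboxylic acid, nor whether a nitrile or a chlorine would join nitro and trifluoromethyl. From the compounds shown here alone, it also remains open whether the same ranking of groups would hold at another place on this aromatic ring or on a changed version of the shared core.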